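Benzyl triazole amides: methoxy to trimethoxy step

The compounds below may be only part of what the source reports. "The series", "measured", "known", "first", "only" and "open" are said of these compounds alone.

Compound 1 `O=C(NCc1cn(Cc2ccc(C(F)(F)F)cc2)nn1)c1cn(-c2ccccc2)nc1-c1ccc(F)cc1` and compound 2 `COc1ccc(Cn2cc(CNC(=O)c3cn(-c4ccccc4)nc3-c3ccc(F)cc3)nn2)cc1` share one core and differ in a single substituent. In a functional assay on HeLa cells (Homo sapiens) for antiproliferative activity, read by sulforhodamine B assay, with a stated time of 48 h (on this read-out higher numbers stand for weaker inhibition of growth and lower numbers for stronger inhibition of growth), compound 1 gives 250 nM, while compound 2 gives 870 nM. Going by the values given here, the only measured step, a 3.5-fold higher number from compound 1 to compound 2 (0.54 log units; beyond the scatter), places compound 2 at the higher of the two numbers, with compound 1 as its sole neighbour.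

Compound 3 `COc1cc(Cn2cc(CNC(=O)c3cn(-c4ccccc4)nc3-c3ccc(F)cc3)nn2)cc(OC)c1OC` is the next member. It differs from compound 2 by 3,4,5-trimethoxyphenyl in place of 4-methoxyphenyl on a saturated chain carbon bound to an aromatic nitrogen. Among the compounds with values here, the one measured step, a 3.5-fold higher number from compound 1 to compound 2 (0.54 log units; beyond the scatter), concerns an exchange of a substituent on the same phenyl, not the addition of two further methoxy groups; no measured pair speaks to that addition. The expectation for compound 3 in this assay is therefore a step of about a 1.1-fold higher number from compound 2 to compound 3 (0.06 log units; within the scatter), with the direction uncertain and a wide range. Compound 3 is estimated at 1000 nM, between 350 nM and 3000 nM.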

Compound 3, concentration for 50% growth inhibition: 2100 nM
Beside the measured number, compound 3's estimate is 2.1-fold (0.32 log units) below it, and the stated range covers the measured number.
By their numbers in this assay, from the lowest: compound 1; then compound 2; then compound 3.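

Working notes: in this assay, 3,4,5-trimethoxyphenyl in place of 4-methoxyphenyl gives a 2.4-fold higher number from compound 2 to compound 3 (0.38 log units; beyond the scatter), so the added methoxy groups on this ring carry a cost beyond the scatter rather than leaving the number unchanged. Measured against the trifluoromethyl member, the same position now spans an 8.4-fold higher number from compound 1 to compound 3 (0.92 log units; beyond the scatter), which shows that the group on the saturated chain carbon bound to an aromatic nitrogen separates all three compounds. No measurement shown here accounts for this order.

A dimethoxyphenyl group would show whether the number climbs gradually with each methoxy group or only with the full trimethoxy pattern. Going by these compounds, whether an unsubstituted phenyl or a chlorophenyl group would fall nearer compound 1 or compound 2 remains open.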